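Swapping the piperazine for a piperidine on the aniline

This account rests on a few compounds, and the source may have more. Where it says the series, first, only, none or still open, it means among the compounds named here.

Measured compounds in a functional assay on MDA-MB-231 cells (Homo sapiens) for inhibition, read by MTT assay, with a stated time of 48 h; on this read-out higher numbers stand for weaker inhibition and lower numbers for stronger inhibition: compound 1 `CC1CCN(c2ccc(Nc3ncc4c(n3)N(C3CCCC3)CC(=O)N4)cc2)CC1` gives 22700 nM; compound 2 `CC1CCN(c2ccc(Nc3ncc4c(n3)N(C3CCCC3)CC(=O)N4C)cc2)CC1` gives > 30000 nM, which is a limit of the assay; compound 3 `CCN1C(=O)CN(C2CCCC2)c2nc(Nc3ccc(N4CCN(C)CC4)cc3)ncc21` gives 26200 nM.

Compound 3 stands highest of the two numbers shown, its nearest neighbour being compound 1, and that gap lies within the scatter. Going by the values given here, the single measured step, an at least 1.3-fold higher number from compound 1 to compound 2 (0.12 log units; that floor lies within the scatter), is a change at the amide-type ring nitrogen and bottoms out at a limit, as noted in the limit of > 30000 nM in this assay, at which 1 of the 3 values shown sits.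

Compound 4 `CCN1C(=O)CN(C2CCCC2)c2nc(Nc3ccc(N4CCC(C)CC4)cc3)ncc21` differs from compound 3 only on the aromatic ring: 4-methylpiperidin-1-yl in place of 4-methylpiperazin-1-yl on an aromatic carbon. Among the compounds with values here, no measured pair isolates this change, so the step from compound 1 to compound 2 is only an indirect guide: it shows that small changes on this core leave the numbers near the top of the range or at the limit. Compound 1, which already carries the 4-methylpiperidin-1-yl group, sits close to compound 3, so no shift beyond the scatter is expected in this assay. Compound 4 is therefore estimated at 28000 nM, between 11000 nM and 75000 nM, a step of a 1.1-fold higher number from compound 3 to compound 4 (0.03 log units; within the scatter) that is expected to stay within the scatter.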

Compound 4, half-maximal inhibitory concentration: > 30000 nM
Compound 4 ended at the assay's limit; the forecaster's own chance of this, stated with the estimate: 40%; middle value at least 1.0-fold (0.02 log units) from the limit.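

In this assay, 4-methylpiperidin-1-yl in place of 4-methylpiperazin-1-yl on an aromatic carbon now has a measured pair of its own, and it gives an at least 1.1-fold higher number from compound 3 to compound 4 (0.05 log units; that floor lies within the scatter). Trading the second ring nitrogen for carbon therefore produces no shift that can be told from the scatter, although the limit leaves the true size of the step unknown. With the 4-methylpiperidin-1-yl group held fixed, ethyl in place of hydrogen on the amide-type ring nitrogen gives an at least 1.3-fold higher number from compound 1 to compound 4 (0.12 log units; that floor lies within the scatter), so this ethyl change, like the methyl change on the same nitrogen, ends at the limit, and the step from compound 2 to compound 4 cannot be read because both values are limits: the limit of > 30000 nM in this assay, at which 2 of the 4 values shown sit.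

The compounds shown leave open how far past the limit compound 2 and compound 4 lie, and so whether the 4-methylpiperidin-1-yl group and the ethyl group change anything at all in this range. They also leave open what a morpholine or a primary amine would give at this place on the aromatic ring, and what a longer chain would give on the amide-type ring nitrogen.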